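This account rests on a few compounds, and the source may have more. Where it says the series, first, only, none or still open, it means among the compounds named here.

Measured in a functional assay on HL-60 cells (Homo sapiens) for cytotoxicity, read by MTT assay, with a stated time of 48 h (a lower number here means a stronger inhibitor, a higher number a weaker inhibitor), so far:
compound 1 (`COc1cc(O)c2c(c1O)C/C(C)=C\[C@@H](O)C[C@@]1(C)O[C@@H]1C2=O`) gives 17800 nM in this series
compound 2 (`COc1cc(O)c2c(c1O)C[C@]1(C)O[C@@H]1CC[C@@]1(C)O[C@@H]1C2=O`) gives 4000 nM in this series

Compound 1 holds the higher of the two numbers, which makes it the weaker inhibitor of the pair. The number for compound 2 lies lower by a margin beyond the usual scatter.

Compound 3 (`COc1cc(O)c2c(c1O)C/C(C)=C\CC[C@@]1(C)O[C@@H]1C2=O`) has not yet been measured. It departs from compound 1 by a single change, hydrogen in place of hydroxy on a saturated ring carbon in all: hydrogen in place of hydroxy on a saturated ring carbon. Within the data shown here, no pair of measured compounds isolates this change, and compound 2 differs from compound 1 in more than one place, so the series offers no direct precedent.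

In this assay the expected step is small, probably none beyond the scatter, with only a slight lean toward a lower number. The estimated shift is a 1.5-fold lower number from compound 1 to compound 3 (0.17 log units; within the scatter) and remains an expectation. For compound 3 the estimated value is 12000 nM with an expected range from 4000 nM to 30000 nM as a working figure.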

Compound 3, half-maximal inhibitory concentration: 5600 nM
For compound 3 the middle estimate is 2.1-fold (0.33 log units) above the measured one, and the stated range covers the measured number.
By their numbers in this assay, from the lowest: compounds 2 and 3 (each within the scatter of the next); then compound 1.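

Hydrogen in place of hydroxy on a saturated ring carbon gives, in this assay, a 3.2-fold lower number from compound 1 to compound 3 (0.50 log units; beyond the scatter), the first step in the series that isolates a single change. The hydroxy at this position is therefore not required for cytotoxicity on these cells, and of this pair the compound without it is the stronger inhibitor. Nothing at hand accounts for the size or direction of this step.

Hydroxy and hydrogen are the only two groups seen on this carbon, so it remains open whether a methoxy group, an amine or a fluorine atom there would keep the number near that of compound 3 or move it back toward that of compound 1. On these data alone, it also remains open whether the step carries over to other cell lines, as the comparison rests on one pair in this assay.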